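Difluorophenyl for methoxyphenyl: the second instance

The source may hold more compounds than are shown below. What is called first, only, known or untested is meant among the compounds shown, and "the series" means these compounds.

Four compounds share a saturated ring bearing a hydroxyl and a benzylic arm, and differ in the arm and in the group on the other side of the ring. Compound 1 is `COc1ccc(C[C@H]2CC[C@](O)(CC(=O)Nc3ccc4[nH]c(=O)oc4c3)CC2)cc1` and compound 2 is `O=C(C[C@]1(O)CC[C@@H](Cc2ccc(F)c(F)c2)CC1)Nc1ccc2[nH]c(=O)oc2c1`. Compound 3 is `COc1ccc(C[C@H]2CC[C@](O)(Cc3cc(-c4cn[nH]c4)on3)CC2)cc1`, and compound 4, not yet measured, is `O[C@]1(Cc2cc(-c3cn[nH]c3)on2)CC[C@H](Cc2ccc(F)c(F)c2)CC1`. The difference between the core of compound 1 and the core of compound 3 is not broken down here.

In an ADME assay on the whole organism (strain Sprague-Dawley) for pharmacokinetics, with Rattus norvegicus as the target, using cassette dosing, at a dose of 1 mg/kg by the oral route (a higher number here means that a larger share of the oral dose reaches the circulation, a lower number that a smaller share of the oral dose reaches the circulation), compound 1 gives 16%. Compound 2 gives 12.1% in this assay. The change between them is 3,4-difluorophenyl in place of 4-methoxyphenyl on a saturated chain carbon bound to a saturated ring carbon, and the step it made is a number 3.9 percentage points lower from compound 1 to compound 2 (within the scatter). Compound 3 gives 23.7% in this assay; its value and that of compound 1 lie within the scatter of each other, while the value of compound 2 lies beyond the scatter below it.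

Compound 4 carries the same change relative to compound 3: 3,4-difluorophenyl in place of 4-methoxyphenyl on a saturated chain carbon bound to a saturated ring carbon, at the same place as before. Among the compounds with values here, only one earlier instance exists, and it lay within the scatter, so the present expectation is a flat to slightly lower value on the new core. The expected step is a number 4.2 percentage points lower from compound 3 to compound 4 (within the scatter). This expectation rests on the step of a number 3.9 percentage points lower from compound 1 to compound 2 (within the scatter) carried over unchanged. Compound 4 is thus expected to give 19.5% in this assay, with a range from 9% to 30%.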

Compound 4, oral bioavailability: 67.5%
Compound 4: middle estimate off by 48 percentage points, on the low side, outside the stated range (above it).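

On the core of compound 3, 3,4-difluorophenyl in place of 4-methoxyphenyl gives, in this assay, a number 43.8 percentage points higher from compound 3 to compound 4 (beyond the scatter), so the step seen on the core of compound 1 does not serve as a guide on this second core. Set side by side, the two instances of the same change disagree, and the size of the step depends on the core it is made on: the same change on two cores in this assay, a number 3.9 percentage points lower (within the scatter) from compound 1 to compound 2 and a number 43.8 percentage points higher (beyond the scatter) from compound 3 to compound 4, 47.7 percentage points apart, beyond the scatter of two such steps

Within the data shown here, this does not show which part of the core sets the size of the step, since the two cores differ by more than one feature and no compound here separates those features; nor do two instances support a general rule for this change, in either direction, on any further core.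

From the compounds shown here alone, what stays open is whether a plain phenyl or a 4-chlorophenyl in the same place on the core of compound 3 would give a value near that of compound 3 or near that of compound 4. Also open, going by these compounds, is whether a nitrile or a trifluoromethyl on that phenyl ring would keep the high value of compound 4, and whether the amide arm of compound 1 could be brought to such a value by any such change.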